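The source may hold more compounds than are shown below. What is called first, only, known or untested is meant among the compounds shown, and "the series" means these compounds.

Measured compounds in a functional assay on FM3A cells (Mus musculus) for cytotoxicity, read by cell counting, with a stated time of 2 days; a higher number here means a weaker inhibitor, a lower number a stronger inhibitor:

Compound 1, `CC(C)(C)c1ccc(CN2C(=O)S/C(=C\c3ccc(N)cc3)C2=O)cc1`: 80000 nM
Compound 2, `Nc1ccc(/C=C2\SC(=O)N(Cc3ccccc3)C2=O)cc1`: 24000 nM
Compound 3, `C=C(Br)C(=O)Nc1ccc(/C=C2\SC(=O)N(Cc3ccccc3)C2=O)cc1`: 3000 nM

Compound 2 stands second highest of the three numbers in this assay; its nearest neighbour is compound 1 (a 3.3-fold lower number from compound 1 to compound 2 (0.52 log units; beyond the scatter)), its furthest compound 3 (an 8.0-fold lower number from compound 2 to compound 3 (0.90 log units; beyond the scatter)).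

Compound 4, `CCN1C(=O)S/C(=C\c2ccc(N)cc2)C1=O`, has not yet been measured. It differs from compound 2 in one place:

methyl in place of phenyl on a saturated chain carbon bound to an amide-type nitrogen in a ring

Going by the values given here, of the two measured steps, only the step from compound 1 to compound 2 touches the same side of the shared core, the group carried on the amide-type nitrogen of the ring; there, loss of tert-butyl gave a 3.3-fold lower number from compound 1 to compound 2 (0.52 log units; beyond the scatter). The step from compound 2 to compound 3, an 8.0-fold lower number from compound 2 to compound 3 (0.90 log units; beyond the scatter), sits on the nitrogen on the aromatic ring and does not bear on the present change. One step in the relevant region is thin evidence, and it removes a substituent on the phenyl rather than the phenyl itself, so the direction for compound 4 is uncertain; a modest step either way, or none beyond the scatter, seems plausible, with a slight lean toward a lower number because of a 3.3-fold lower number from compound 1 to compound 2 (0.52 log units; beyond the scatter). The expected step is a 1.6-fold lower number from compound 2 to compound 4 (0.20 log units; within the scatter). Compound 4 is therefore estimated at 15000 nM in this assay, within 4000 nM to 60000 nM.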

Compound 4, half-maximal inhibitory concentration: 76000 nM
Estimate against measurement, compound 4: 5.1-fold (0.70 log units) below; measured number above the stated range.
By their numbers in this assay, from the lowest: compound 3; then compound 2; then compounds 4 and 1 (each within the scatter of the next).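

Working from compound 2, the group on the amide-type nitrogen now has a measured step that removes the phenyl itself, not just a substituent on it: a 3.2-fold higher number from compound 2 to compound 4 (0.50 log units; beyond the scatter) in this assay. Read with a 3.3-fold lower number from compound 1 to compound 2 (0.52 log units; beyond the scatter), this shows that the number rises on both sides of the unsubstituted benzyl of compound 2, so among compounds 1, 2 and 4 the number does not follow the size of this group in a single direction. Nothing available here explains the rise on going from benzyl to ethyl at this position.

Open, as far as these compounds go, is how a longer chain such as butyl, or an amine or a carboxylic acid on the benzyl phenyl, would read in this assay. Also open, from the compounds shown here alone, is whether an 8.0-fold lower number from compound 2 to compound 3 (0.90 log units; beyond the scatter) would carry over to the ethyl series of compound 4.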